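This account rests on a few compounds, and the source may have more. Where it says the series, first, only, none or still open, it means among the compounds named here.

Measured compounds: compound 1 `Oc1c(C(Nc2ccccn2)c2c(Cl)cccc2Cl)ccc2cccnc12` and compound 2 `Oc1ccc2[nH]ncc2c1C(c1ccc(-n2cccc2)cc1)N1CCCCC1`.

In an assay for inhibition of protein disulfide-isomerase (Homo sapiens), with a stated time of 1 h (a lower number here means a stronger inhibitor, a higher number a weaker inhibitor), compound 1 gives 1890 nM. In this assay compound 2 gives 290 nM. Among these two numbers compound 2 stands lowest; its only neighbour, compound 1, sits well above it, and that gap lies beyond the scatter. The two compounds share no single-point change, so their two values show only that much.

Compound 3 `O=[N+]([O-])c1ccc(C(c2c(O)ccc3[nH]ncc23)N2CCCCC2)cc1` is the next entry. It differs from compound 2 in one place: nitro in place of 1H-pyrrol-1-yl on an aromatic carbon. For the measured compounds named here, no pair of measured compounds carries this change, so nothing in the present numbers says how large a step it brings. Taking compound 2 with its 290 nM as the reference, the step of a 1.7-fold higher number from compound 2 to compound 3 (0.24 log units; within the scatter) is expected to be small, at most a mild loss, and may sit within the scatter. Compound 3 is therefore estimated at 500 nM, with a range from 120 nM to 2000 nM.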

Compound 3, half-maximal inhibitory concentration: 520 nM
Beside the measured number, compound 3's estimate is 1.0-fold (0.02 log units) below it, and the stated range covers the measured number.
By their numbers in this assay, from the lowest: compounds 2 and 3 (each within the scatter of the next); then compound 1.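

The series now has its first single-place comparison: in this assay, nitro in place of 1H-pyrrol-1-yl on an aromatic carbon, para to a large group, gives a 1.8-fold higher number from compound 2 to compound 3 (0.25 log units; within the scatter). For this pair, then, replacing a five-membered aromatic ring with a nitro group, which carries no ring and fewer heavy atoms, leaves the value within the scatter. No accompanying measurement bears on why the two groups read alike.

Going by these compounds, whether an amine, a carboxylic acid or a longer chain on this carbon would also stay within the scatter remains open. Also open is what the other parts of compound 2 and compound 3 contribute, since the only single-place change shown lies at this carbon.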